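Thiophen-2-yl to thiophen-3-yl in the series

The source may hold more compounds than are shown below. What is called first, only, known or untested is meant among the compounds shown, and "the series" means these compounds.

Among the measured compounds shown here, in a functional assay on U-937 cells (Homo sapiens), read by cAMP accumulation (on this read-out higher numbers stand for an effect only at larger amounts of compound and lower numbers for an effect already at smaller amounts), compound 3 (`CCc1nn(C2CCCC2)c2c1CCN(c1cccs1)C2=O`) gives 1 nM, the lowest of the three numbers so far. Compound 1 (`CCc1nn(C2CCCC2)c2c1CCN(c1ccccc1)C2=O`) gives 70 nM and compound 2 (`CCc1nn(C2CCCC2)c2c1CCN(c1cccc(OC)c1)C2=O`) gives 330 nM. Compound 4 (`CCc1nn(C2CCCC2)c2c1CCN(c1ccsc1)C2=O`) is not yet measured. It carries thiophen-3-yl in place of thiophen-2-yl on an amide-type nitrogen in a ring.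

Changes of the group at that place gave large steps, a 70-fold lower number from compound 1 to compound 3 (1.85 log units; beyond the scatter) and a 330-fold lower number from compound 2 to compound 3 (2.52 log units; beyond the scatter), while the methoxy change alone gave a modest one, a 4.7-fold higher number from compound 1 to compound 2 (0.67 log units; beyond the scatter). For the measured compounds named here, no measured pair compares thiophen-2-yl with thiophen-3-yl directly, so the evidence is indirect. Going by the values given here, since compound 3 holds the lowest value, and the group change from compound 1 moved the number so far, a modest move to a higher number is expected in this assay, well short of the full gap to compound 1. The expected step is a 6.0-fold higher number from compound 3 to compound 4 (0.78 log units; beyond the scatter). Compound 4 is estimated at 6 nM, with an expected range of 1.5 nM to 30 nM.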

Compound 4, half-maximal effective concentration: 36 nM
The estimate for compound 4 lay 6.0-fold (0.78 log units) below the measured number; the whole stated range lies below it.
By their numbers in this assay, from the lowest: compound 3; then compounds 4 and 1 (each within the scatter of the next); then compound 2.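

In this assay the two thiophene isomers are far apart at the amide-type nitrogen in a ring (a 36-fold higher number from compound 3 to compound 4 (1.56 log units; beyond the scatter)), although thiophen-2-yl and thiophen-3-yl have the same atoms and the same counts of donors and acceptors. The low number of compound 3 therefore belongs to thiophen-2-yl and not to any thiophene at this place. Thiophen-3-yl cannot be told apart from phenyl (a 1.9-fold lower number from compound 1 to compound 4 (0.29 log units; within the scatter)) but still stands clear of 3-methoxyphenyl (a 9.2-fold lower number from compound 2 to compound 4 (0.96 log units; beyond the scatter)).

As far as these compounds go, whether the thiophen-2-yl result holds with a methyl group or chlorine on the thiophene, or with furan-2-yl or thiazol-2-yl at the same place, stays open. What a longer chain or an amine would do in place of the ethyl or cyclopentyl group cannot be read from these compounds. No measurement at hand accounts for the gap between the two isomers.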